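A few compounds are considered here, and "the series" means these few. Any claim that something is new, unique, unknown or untested is made for them only; others in the source may bear on it.

Compound 1 `COc1cc(Oc2cccc(Nc3ccccc3)c2)cc(OC)c1CNC1CC1` is one of a small set of compounds built on the shared core and tested in a functional assay on HCT-15 cells (Homo sapiens) for inhibition, read by MTT assay, with a stated time of 72 h; on this read-out higher numbers stand for weaker inhibition and lower numbers for stronger inhibition. In this assay compound 1 gives 6140 nM, the highest of the two numbers recorded; its nearest neighbour is compound 2 `COc1cc(Oc2cccc(Nc3ccccc3)c2)cc(OC)c1CNCCNC(C)=O`, which gives 5090 nM, so that the pair lie within the scatter a 1.2-fold lower number from compound 1 to compound 2 (0.08 log units; within the scatter). Compound 3 `COc1cc(Oc2cccc(Nc3ccccc3)c2)cc(OC)c1CNC(C)C` is reported only as a limit, > 20000 nM. Compound 4 `COc1cc(Oc2cccc(Nc3ccccc3)c2)cc(OC)c1CNCc1ccccc1` has not yet been measured; it differs from compound 1 by benzyl in place of cyclopropyl on an amine nitrogen. Among the compounds with values here, two measured steps bear on this change at the same amine nitrogen: the move to 2-acetamidoethyl, which gave a 1.2-fold lower number from compound 1 to compound 2 (0.08 log units; within the scatter), and the move to isopropyl, which gave an at least 3.2-fold higher number from compound 1 to compound 3 (0.51 log units; beyond the scatter), with compound 3 sitting at the limit of > 20000 nM in this assay, at which 1 of the 3 values shown sits. Neither step involves a benzyl group, so the direction for compound 4 is uncertain; compound 2 and compound 3 together suggest an outcome anywhere from no change beyond the scatter to a weakening. Compound 4 is therefore expected to give about 6000 nM, with a range of 2000 nM to 20000 nM, which means an estimated step of a 1.0-fold lower number from compound 1 to compound 4 (0.01 log units; within the scatter).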

Compound 4, half-maximal inhibitory concentration: 5020 nM
The estimate for compound 4 lay 1.2-fold (0.08 log units) above the measured number, within the range that was stated.
By their numbers in this assay, from the lowest: compounds 4, 2 and 1 (each within the scatter of the next). At a limit, above all of these: compound 3.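

In this assay, benzyl on the amine nitrogen brings an aromatic ring in place of the three-membered ring of cyclopropyl, yet the number stays within the scatter: a 1.2-fold lower number from compound 1 to compound 4 (0.09 log units; within the scatter). Compound 4 also matches the 2-acetamidoethyl compound, a 1.0-fold lower number from compound 2 to compound 4 (0.01 log units; within the scatter), but it separates from the isopropyl compound, an at least 3.9-fold lower number from compound 3 to compound 4 (0.60 log units; beyond the scatter), so three quite different groups now sit together and compound 3 alone goes against them. The figure for compound 3 is a limit, not a number: the limit of > 20000 nM in this assay, at which 1 of the 4 values shown sits.

From the compounds shown here alone, whether a phenethyl or a cyclohexylmethyl group on this nitrogen would stay with compound 1, compound 2 and compound 4 remains open, which leaves the role of the aromatic ring unsettled. Also open, going by these compounds, is whether an ethyl or a tert-butyl group would follow compound 3.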